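The compounds below may be only part of what the source reports. "The series", "measured", "known", "first", "only" and "open" are said of these compounds alone.

Measured in a functional assay on HCT-116 cells (Homo sapiens) for antiproliferative activity, read by sulforhodamine B assay, with a stated time of 72 h; a higher number here means a weaker inhibitor, a lower number a stronger inhibitor:
- compound 1 `CNC(=O)C[C@@H]1C[C@@H](c2ccc(Cl)c(Cl)c2)[C@H](NC(=O)c2cc(-c3c(Cl)cnn3C)c(Cl)o2)CN1`: 450 nM
- compound 2 `Cn1ncc(Cl)c1-c1cc(C(=O)N[C@@H]2CN[C@H](CC(=O)NCC(O)CO)C[C@H]2c2ccc(Cl)c(Cl)c2)oc1Cl`: 7090 nM
- compound 3 `CCC[C@@H]1C[C@@H](c2ccc(Cl)c(Cl)c2)[C@H](NC(=O)c2cc(-c3c(Cl)cnn3C)c(Cl)o2)CN1`: 1020 nM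

Compound 3 holds the middle place of the three numbers, with a 2.3-fold higher number from compound 1 to compound 3 (0.36 log units; beyond the scatter) and a 7.0-fold lower number from compound 2 to compound 3 (0.84 log units; beyond the scatter). The next compound, compound 4 `Cn1ncc(Cl)c1-c1cc(C(=O)N[C@@H]2CN[C@H](CC(=O)NC3CC3)C[C@H]2c2ccc(Cl)c(Cl)c2)oc1Cl`, has cyclopropylcarbamoyl in place of ethyl on a saturated chain carbon bound to a saturated ring carbon.

The two steps to compound 3 bear most directly on this change, and they run in opposite directions. A carbamoyl group alone therefore does not fix the direction in this assay. What sits on the amide nitrogen counts as well, as shown by a 16-fold higher number from compound 1 to compound 2 (1.20 log units; beyond the scatter). No cyclopropyl amide has been measured, but compound 4 lacks the two hydroxyl groups of compound 2 and is the closer match to compound 1.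

A modest fall in the number is therefore expected, and the expected step is a 2.0-fold lower number from compound 3 to compound 4 (0.31 log units; beyond the scatter). For compound 4 the estimated value is 500 nM, with an expected range of 170 nM to 1500 nM.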

Compound 4, half-maximal inhibitory concentration: 740 nM
The estimate for compound 4 lay 1.5-fold (0.17 log units) below the measured number; the range from low to high includes it.
By their numbers in this assay, from the lowest: compounds 1, 4 and 3 (each within the scatter of the next, the first and the last beyond it); then compound 2.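

In this assay, cyclopropylcarbamoyl on a saturated chain carbon bound to a saturated ring carbon does not separate from the ethyl of the shorter chain in compound 3 (a 1.4-fold lower number from compound 3 to compound 4 (0.14 log units; within the scatter)). On the amide-type nitrogen, cyclopropyl and methyl are likewise not separated (a 1.6-fold higher number from compound 1 to compound 4 (0.22 log units; within the scatter)), whereas replacing 2,3-dihydroxypropyl with cyclopropyl gives a step beyond the scatter (a 9.6-fold lower number from compound 2 to compound 4 (0.98 log units; beyond the scatter)), so among these three amides only compound 2 stands apart. No measured evidence bears on what lies behind these steps.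

Still open, going by these compounds, is how a primary amine or a carboxylic acid would read on this saturated chain carbon. Also open, on these data alone, is whether 2-hydroxyethyl or a longer unbranched chain on the amide-type nitrogen would group with compound 2 or with compounds 1 and 4.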